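The source may report more compounds than this note shows. Statements on the series, on what has been measured and on what is new or still open speak of the compounds shown alone.

Compound 1 `Nc1scc(CN2CCN(c3cc(Cl)cc(Cl)c3)CC2)c1C(=O)c1ccc(Cl)cc1` and compound 2 `Nc1scc(CN2CCN(c3ccc(F)cc3Cl)CC2)c1C(=O)c1ccc(Cl)cc1` share one core and differ only in the aromatic group attached to the amine nitrogen in a ring. In a functional assay on CHO cells with adenosine receptor A1 (Homo sapiens) as the target, read by cAMP accumulation and immunoassay, with a stated time of 6 min, tested at 1 uM (a higher number here means a weaker effect of the compound at the concentration tested, a lower number a stronger effect), compound 1 gives -69%, while compound 2 gives -39%. Among the compounds with values here, that exchange of aromatic groups brought a number 30 percentage points higher from compound 1 to compound 2 (beyond the scatter), so compound 2 stands as the higher of the two numbers measured so far, which means the weaker effect at the tested concentration. Compound 3 `Nc1scc(CN2CCN(c3ccc(Cl)cc3F)CC2)c1C(=O)c1ccc(Cl)cc1` is the next step: 4-chloro-2-fluorophenyl in place of 2-chloro-4-fluorophenyl on an amine nitrogen in a ring. The two compounds have the same atoms, joined differently. Within the data shown here, the only measured step, a number 30 percentage points higher from compound 1 to compound 2 (beyond the scatter), concerns a different exchange of aromatic groups, and no measured pair shows what rearranging the same halogens on the same aromatic ring does in this assay. With nothing to go on beyond compound 2 itself, no step beyond the usual scatter is assumed, and no change at the digits printed from compound 2 to compound 3 (within the scatter) is the estimated step. Compound 3 is therefore expected to give -39% in this assay, with an estimated range from -65% to -13%.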

Compound 3, a percentage reported as activity, at one concentration (the size of the read-out at that concentration, not a potency): -57%
Estimate against measurement, compound 3: 18 percentage points above; the range from low to high includes it.
By their numbers in this assay, from the lowest: compound 1; then compound 3; then compound 2.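

Exchanging the chlorine and fluorine positions on the aromatic ring, with the same atoms and the same counts, is enough to change the read-out in this assay: the exchange gives a number 18 percentage points lower from compound 2 to compound 3 (beyond the scatter) and so shows that this position responds to how the two halogens are arranged, not only to which halogens are present. The 4-chloro-2-fluorophenyl group does not match the 3,5-dichlorophenyl group, with a number 12 percentage points higher from compound 1 to compound 3 (beyond the scatter) in this comparison, so the three aromatic groups now form an order in which compound 1 has the strongest effect at the tested concentration, compound 3 an intermediate one and compound 2 the weakest. No measurement here bears on the cause of these differences.

From the compounds shown here alone, all three aromatic groups carry two halogens, so it remains open whether a phenyl ring with a single chlorine, with no halogen at all, or with a methoxy group or a nitrile would give a stronger or weaker effect. Going by these compounds, it also remains open whether moving the halogens would produce a step of similar size and direction on a different core.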